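The source may report more compounds than this note shows. Statements on the series, on what has been measured and on what is new or still open speak of the compounds shown alone.

Compound 1 `CC(C)n1cnc2c(NCc3ccc(C(=O)Nc4ccccc4N)cc3)nc(Cl)nc21` gives 80.5% in a functional assay on NCI-H460 cells (Homo sapiens) for antiproliferative activity, read by CCK-8 assay, with a stated time of 72 h, tested at 8 uM; a lower number here means a weaker effect, a higher number a stronger effect of the compound at the concentration tested.
Compound 2 `Nc1ccccc1NC(=O)c1ccc(CNc2nc(Cl)nc3c2ncn3Cc2ccccc2)cc1` gives 46.4%.

Compound 2 stands lowest of the two measured numbers. Compound 3 `CCCn1cnc2c(NCc3ccc(C(=O)Nc4ccccc4N)cc3)nc(Cl)nc21` differs from compound 2 by ethyl in place of phenyl on a saturated chain carbon bound to an aromatic nitrogen. Going by the values given here, the only measured step that bears on this, a number 34.1 percentage points lower from compound 1 to compound 2 (beyond the scatter), went in the opposite direction. Since the change here partly undoes that step, compound 3 is expected to move back upward by roughly a number 23.6 percentage points higher from compound 2 to compound 3 (beyond the scatter), though not all the way. The estimated value for compound 3 is 70%, within a range from 50% to 88%.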

Compound 3, a percentage reported as inhibition, at one concentration (the size of the read-out at that concentration, not a potency): 39.2%
Compound 3: the middle estimate sits 30.8 percentage points above what was measured; measured number outside the range, below it.
By their numbers in this assay, from the lowest: compounds 3 and 2 (each within the scatter of the next); then compound 1.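

In this assay, replacing benzyl with propyl gives a number 7.2 percentage points lower from compound 2 to compound 3 (within the scatter), so removing the phenyl ring does not restore the number seen for compound 1. Changing isopropyl to propyl gives a number 41.3 percentage points lower from compound 1 to compound 3 (beyond the scatter), which shows that a small chain alone is not enough at this aromatic nitrogen: among these groups, only isopropyl stands apart. No measurement here explains this difference. Still open, as far as these compounds go, is whether other branched groups, such as tert-butyl, behave like isopropyl. Ethyl, cyclopropyl and a longer chain ending in an amine also remain open.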